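One change at the carbonyl carbon of compound 1

This account rests on a few compounds, and the source may have more. Where it says the series, first, only, none or still open, it means among the compounds named here.

Compound 1, `COc1ccc(CN(C(C)=O)c2cc(OC)c(OC)c(OC)c2)cc1O`: 79 nM
Compound 2, `COc1cc(NCc2cccc(O)c2)cc(OC)c1OC`: 57600 nM
Compound 3, `COc1cc(NCc2ccccc2)cc(OC)c1OC`: > 80000 nM, a limit of the assay rather than a number

In a functional assay on MGC-803 cells (Homo sapiens) for inhibition, read by MTT assay, with a stated time of 48 h (on this read-out lower numbers stand for stronger inhibition and higher numbers for weaker inhibition), compound 1 gives 79 nM, the lowest of the numbers shown, and compound 2 gives 57600 nM. For compound 3 the reading is the limit of > 80000 nM in this assay, at which 1 of the 3 values shown sits. Within the data shown here, the only measured step, an at least 1.3-fold higher number from compound 2 to compound 3 (0.14 log units; that floor lies within the scatter), concerns a hydroxy group on an aromatic carbon and does not touch the amide. Compound 4, `COc1ccc(CN(C(=O)/C=C/CBr)c2cc(OC)c(OC)c(OC)c2)cc1O`, differs from compound 1 at the carbonyl carbon: 3-bromoprop-1-en-1-yl in place of methyl on a carbonyl carbon, that is, acetyl to (3-bromoprop-1-en-1-yl)carbonyl. Among the measured compounds shown here, no measured step bears on this change, so the data offer no ground for a shift beyond the scatter in this assay. Compound 4 is therefore expected to stay near compound 1, with a 1.3-fold lower number from compound 1 to compound 4 (0.12 log units; within the scatter) expected to lie within the scatter. The estimate for compound 4 is 60 nM, ranging from 15 nM to 300 nM.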

Compound 4, half-maximal inhibitory concentration: 71 nM
Compound 4: middle estimate off by 1.2-fold (0.07 log units), on the low side, within the range that was stated.
By their numbers in this assay, from the lowest: compounds 4 and 1 (each within the scatter of the next); then compound 2. At a limit, above all of these: compound 3.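

At the carbonyl carbon, the step in this assay, a 1.1-fold lower number from compound 1 to compound 4 (0.05 log units; within the scatter), shows that this position accepts 3-bromoprop-1-en-1-yl in place of methyl with no shift beyond the scatter. Among these compounds, the earlier compounds offered no step at this carbon, so this is the first reading of the position. Nothing measured here bears on why the number holds. The compounds shown leave open whether an amine, a carboxylic acid or a longer saturated chain on this carbonyl carbon would hold the number as well. They also leave open how the double bond and the bromine each count, as the two enter together.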